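The source may report more compounds than this note shows. Statements on the series, on what has been measured and on what is new or still open speak of the compounds shown alone.

In a functional assay on HepG2 cells (Homo sapiens) for antiproliferative activity, read by sulforhodamine B assay, with a stated time of 48 h (on this read-out higher numbers stand for weaker inhibition and lower numbers for stronger inhibition), three compounds sharing one core have been measured. Compound 1 (`COc1ccc(C=C(C(=O)/C=C/c2cccc(OC)c2OC)C(=O)/C=C/c2cccc(OC)c2OC)cc1OC`) gives 200 nM, compound 2 (`COc1cc(OC)c(C=C(C(=O)/C=C/c2cccc(OC)c2OC)C(=O)/C=C/c2cccc(OC)c2OC)c(OC)c1`) gives 300 nM, and compound 3 (`COc1cccc(/C=C/C(=O)C(=Cc2ccc(OC)c(OC)c2OC)C(=O)/C=C/c2cccc(OC)c2OC)c1OC`) gives 240 nM. These three values lie within the scatter of one another, so compound 3 holds no separate rank among them.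

Compound 4 (`COc1ccc(C=C(C(=O)/C=C/c2cccc(OC)c2OC)C(=O)/C=C/c2cccc(OC)c2OC)cc1O`) differs from compound 3 in one place: 3-hydroxy-4-methoxyphenyl in place of 2,3,4-trimethoxyphenyl on a double-bonded chain carbon bound to a double-bonded chain carbon. In words, 3-hydroxy-4-methoxyphenyl stands in place of 2,3,4-trimethoxyphenyl on a double-bonded chain carbon bound to a double-bonded chain carbon.

The measured steps that bear on this all change the group at that same place. They are a 1.5-fold higher number from compound 1 to compound 2 (0.18 log units; within the scatter), a 1.2-fold higher number from compound 1 to compound 3 (0.08 log units; within the scatter) and a 1.3-fold lower number from compound 2 to compound 3 (0.10 log units; within the scatter), and each lies within the scatter. Going by the values given here, none of the measured compounds carries a hydroxy group, however, so the data do not test that feature directly, and the range is kept wide.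

On these steps, no change beyond the scatter is expected in this assay, and the expected step is a 1.1-fold lower number from compound 3 to compound 4 (0.04 log units; within the scatter). For compound 4 the estimated value is 220 nM, with an expected range of 90 nM to 550 nM.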

Compound 4, half-maximal inhibitory concentration: 270 nM
Estimate against measurement, compound 4: 1.2-fold (0.09 log units) below, within the range that was stated.
By their numbers in this assay, from the lowest: compounds 1, 3, 4 and 2 (each within the scatter of the next).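

In this assay the hydroxy group, new to this series, brings no change beyond the scatter at this place: the steps are a 1.1-fold higher number from compound 3 to compound 4 (0.05 log units; within the scatter) and a 1.1-fold lower number from compound 2 to compound 4 (0.05 log units; within the scatter). The closest test is hydrogen in place of methyl on an oxygen on an aromatic ring, which changes only that one feature, and it gives a 1.4-fold higher number from compound 1 to compound 4 (0.13 log units; within the scatter), so a group with a hydrogen-bond donor here stays within the scatter of all three earlier compounds. Nothing measured alongside these values accounts for this result.

Going by these compounds alone, every group at this place so far carries only methoxy or hydroxy substituents on its phenyl ring. The compounds shown leave open whether an amine, a carboxylic acid or a longer alkoxy chain on that ring would move the number beyond the scatter.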